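This account rests on a few compounds, and the source may have more. Where it says the series, first, only, none or still open, it means among the compounds named here.

Compound 1 `Cc1ccc(C2=NN(c3nc(-c4ccc(C#N)cc4)cs3)C(c3ccc(F)cc3)C2)s1` gives 322 ug/mL in a functional assay on A549 cells (Homo sapiens) for antiproliferative activity, read by XTT assay, with a stated time of 24 h; a higher number here means a weaker inhibitor, a lower number a stronger inhibitor.
Compound 2 `O=[N+]([O-])c1ccc(-c2csc(N3N=C(c4ccc(Cl)s4)CC3c3ccc(F)cc3)n2)cc1` reaches only the assay limit, > 500 ug/mL.
Compound 3 `N#Cc1ccc(-c2csc(N3N=C(c4ccc(Cl)s4)CC3c3ccc(F)cc3)n2)cc1` likewise reaches only the assay limit, > 500 ug/mL.

Compound 1 is the only one of the three with an actual number; the other two values are limits, as the limit of > 500 ug/mL in this assay, at which 2 of the 3 values shown sit, records. The step of an at least 1.5-fold higher number from compound 1 to compound 3 (0.19 log units; that floor lies within the scatter) thus has a floor that lies within the scatter, and the step that the two limits leave unreadable from compound 2 to compound 3 cannot be read at all.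

Compound 4 `Cc1ccc(C2=NN(c3nc(-c4ccccc4)cs3)C(c3ccc(F)cc3)C2)s1` differs from compound 1 by hydrogen in place of cyano on an aromatic carbon. For the measured compounds named here, none of the measured steps touches this position in the same way: the one step involving the nitrile, from compound 2 to compound 3, is unreadable, and the other step concerns a different ring. The data therefore give no ground to expect a shift beyond the scatter in this assay in either direction. Compound 4 is estimated at 340 ug/mL, with a range from 150 ug/mL to 600 ug/mL, so that the expected step of a 1.1-fold higher number from compound 1 to compound 4 (0.02 log units; within the scatter) is essentially flat.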

Compound 4, half-maximal inhibitory concentration: > 500 ug/mL
Compound 4: only a limit was reported; the forecaster's own chance of this, stated with the estimate: 35%; middle value at least 1.4-fold (0.16 log units) from the limit.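

For the compounds shown here, replacing the nitrile with hydrogen, which turns 4-cyanophenyl into phenyl, gives an at least 1.5-fold higher number from compound 1 to compound 4 (0.19 log units; that floor lies within the scatter), and this is the first step at this position that can be read at all. In this assay compound 4 gives > 500 ug/mL, which is a limit of the assay and not a number. The step therefore gives only a floor, and no sign that the nitrile can be removed with the value staying measurable, but it cannot show how much the nitrile matters because compound 4 joins the other compounds at the ceiling: the limit of > 500 ug/mL in this assay, at which 3 of the 4 values shown sit.

The compounds shown leave open whether an amine, a carboxylic acid or a methoxy group in this place would give a number rather than a limit. They also leave open how far any such group would move the value from that of compound 1.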